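Moving the Chlorine Around the Benzyl Ring

The compounds below may be only part of what the source reports. "The series", "measured", "known", "first", "only" and "open" are said of these compounds alone.

Measured compounds:
compound 1 `Clc1ccc(Cn2cc(COc3ccccc3)nn2)cc1` — 26.1 ug/mL
compound 2 `Clc1cccc(Cn2cc(COc3ccccc3)nn2)c1` — 27.3 ug/mL
compound 3 `Cc1ccc(OCc2cn(Cc3ccc(Cl)cc3)nn2)cc1` — 17.3 ug/mL

In a physicochemical assay, read by spectrophotometry, with a stated time of 30 min (a higher number here means a weaker inhibitor, a lower number a stronger inhibitor), compound 1 gives 26.1 ug/mL, and compound 2 gives 27.3 ug/mL. Compound 3 gives 17.3 ug/mL in this assay. The change from compound 1 to compound 2 is 3-chlorophenyl in place of 4-chlorophenyl on a saturated chain carbon bound to an aromatic nitrogen, and it produced a step of a 1.0-fold higher number from compound 1 to compound 2 (0.02 log units; within the scatter). Compound 3 differs from compound 1 by methyl in place of hydrogen on an aromatic carbon, with a step of a 1.5-fold lower number from compound 1 to compound 3 (0.18 log units; within the scatter), so all three values sit within the scatter of one another and none can be called the strongest.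

Compound 4 `Cc1ccc(OCc2cn(Cc3cccc(Cl)c3)nn2)cc1` has not yet been measured in this assay. It differs from compound 3 by 3-chlorophenyl in place of 4-chlorophenyl on a saturated chain carbon bound to an aromatic nitrogen. For the measured compounds named here, this is the same change, at the same place, as the one from compound 1 to compound 2; the two pairs differ only in their cores, which is the difference given as methyl in place of hydrogen on an aromatic carbon.

Because a 1.0-fold higher number from compound 1 to compound 2 (0.02 log units; within the scatter) was essentially flat, the expected step from compound 3 to compound 4 is also small, estimated as a 1.0-fold higher number from compound 3 to compound 4 (0.02 log units; within the scatter). Compound 4 is therefore expected to give about 18 ug/mL in this assay, with a likely range from 10 ug/mL to 32 ug/mL. This expectation rests on a single earlier instance of the change and on the small spread among compounds 1, 2 and 3.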

Compound 4, half-maximal inhibitory concentration: 16.3 ug/mL
For compound 4 the middle estimate is 1.1-fold (0.04 log units) above the measured one, within the range that was stated.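

In this assay, putting 3-chlorophenyl in place of 4-chlorophenyl gives nearly the same small step on both cores: the core of compound 1 shows one step (a 1.0-fold higher number from compound 1 to compound 2 (0.02 log units; within the scatter)) and the methyl-bearing core shows the other (a 1.1-fold lower number from compound 3 to compound 4 (0.03 log units; within the scatter)). The methyl group in place of hydrogen also stays within the scatter when it is read on the 3-chlorophenyl compounds (a 1.7-fold lower number from compound 2 to compound 4 (0.22 log units; within the scatter)), so these four compounds cannot be ranked, and the chlorine swap carries from one core to the other in the limited sense that it is flat on both. This does not show that the two chlorophenyl groups are truly equal, since small real differences could hide in the scatter, nor that the swap would stay flat on a third core, and no measurement here offers an explanation for the flat result.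

The compounds shown vary only the chlorophenyl group and one methyl group, so they leave open whether any change in this series would produce a step beyond the scatter. An amine or a carboxylic acid in place of that methyl group, or a longer chain in place of the saturated chain carbon, would be a more demanding test.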